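A few compounds are considered here, and "the series" means these few. Any claim that something is new, unique, unknown or untested is made for them only; others in the source may bear on it.

Two compounds of this series have numbers in a functional assay on HeLa cells (Homo sapiens) for cytotoxicity, read by cell counting, with a stated time of 4 days; a lower number here means a stronger inhibitor, a higher number a weaker inhibitor. Compound 1 `C=C(Br)C(=O)Nc1cccc(/C=C2\SC(=O)N(Cc3ccc(Cl)cc3)C2=O)c1` gives 2700 nM in this assay. Compound 2 `Nc1cccc(/C=C2\SC(=O)N(Cc3cccc(Cl)c3)C2=O)c1` gives 250000 nM in this assay, the highest of the two numbers; its nearest neighbour is compound 1, and the gap between the two lies beyond the scatter. Compound 3 `Nc1cccc(/C=C2\SC(=O)N(Cc3ccc(Cl)cc3)C2=O)c1` is not yet measured in this assay. It differs from compound 2 in one place: 4-chlorophenyl in place of 3-chlorophenyl on a saturated chain carbon bound to an amide-type nitrogen in a ring. Within the data shown here, no step between measured compounds shows the effect of this change alone, and a step of no more than the scatter is expected, as a 1.3-fold lower number from compound 2 to compound 3 (0.10 log units; within the scatter). Compound 3 is therefore estimated at 200000 nM in this assay, within 60000 nM to 600000 nM.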

Compound 3, half-maximal inhibitory concentration: > 250000 nM
Compound 3: no number, only a limit; the forecaster's own chance of this, stated with the estimate: 25%; middle value at least 1.2-fold (0.09 log units) from the limit.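

In this assay, compound 3 carries only a limit of the assay, not a number: the limit of > 250000 nM in this assay, at which 1 of the 3 values shown sits. The step for 4-chlorophenyl in place of 3-chlorophenyl on the saturated chain carbon is a number no lower from compound 2 to compound 3 (the limit leaves the size open) and its size cannot be read, so that change has no measured size. With 4-chlorophenyl held constant, hydrogen in place of (1-bromoethenyl)carbonyl on a nitrogen on an aromatic ring gives the first readable single-place step, an at least 92-fold higher number from compound 1 to compound 3 (1.96 log units; beyond the scatter). Still open, going by these compounds, is whether the bromine is needed on that nitrogen substituent: an acetyl or a plain propenoyl group there would separate the carbonyl from the bromoethenyl part.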